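This account rests on a few compounds, and the source may have more. Where it says the series, first, only, none or still open, it means among the compounds named here.

The series centres on compound 1 `O=C(CC1c2ccccc2N=C(SCCCCCN2CCCC2)N1c1ccc(-c2ccccc2)cc1)NCc1ccc(F)cc1`, which in an assay on cells for inhibition of Voltage-dependent T-type calcium channel subunit alpha-1H (Homo sapiens), read by patch clamp, tested at 10 uM (on this read-out lower numbers stand for less inhibition and higher numbers for more inhibition at the one concentration tested (going by the name of the read-out)), gives 69%. Compound 3 `O=C(CC1c2ccccc2N=C(SCCCCCN2CCCC2)N1c1ccc(-c2ccccc2)cc1)NCc1ccccc1` carries hydrogen in place of fluoro on an aromatic carbon, and in this assay compound 3 gives 73.1%; the step of a number 4.1 percentage points higher from compound 1 to compound 3 (within the scatter) is small. Compound 2 `CN(C)CCCCCSC1=Nc2ccccc2C(CC(=O)NCc2ccc(F)cc2)N1c1ccccc1` rests on a different core, and the difference between the two cores is not broken down here; in this assay compound 2 gives 7%, the lowest of the three numbers, far from compound 1 and compound 3.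

Compound 4 `CN(C)CCCCCSC1=Nc2ccccc2C(CC(=O)NCc2ccccc2)N1c1ccccc1` differs from compound 2 by hydrogen in place of fluoro on an aromatic carbon, the same change that turns compound 1 into compound 3. Because a number 4.1 percentage points higher from compound 1 to compound 3 (within the scatter) stayed within the usual scatter on the core of compound 1, the step from compound 2 to compound 4 is expected to be likewise small, so that the estimated step is a number 3 percentage points higher from compound 2 to compound 4 (within the scatter). On that basis compound 4 is expected to give about 10% in this assay, most likely between 0% and 25%, and the actual measurement is awaited.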

Compound 4, a percentage reported as inhibition, at one concentration (the size of the read-out at that concentration, not a potency): 51.8%
Beside the measured number, compound 4's estimate is 41.8 percentage points below it; the whole stated range lies below it.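

In this assay, going from 4-fluorobenzyl to benzyl on the core of compound 2 gives a number 44.8 percentage points higher from compound 2 to compound 4 (beyond the scatter), so this change cannot be carried from one core to the other as a fixed increment. In this series, its size depends on the core that bears it: the same change on two cores in this assay, a number 4.1 percentage points higher (within the scatter) from compound 1 to compound 3 and a number 44.8 percentage points higher (beyond the scatter) from compound 2 to compound 4, 40.7 percentage points apart, beyond the scatter of two such steps

Among the compounds shown here, this rests on only two matched pairs read at a single concentration, and it says nothing about how the change would behave on any further core. Nor does it show which feature of the cores matters, as compound 1 and compound 2 differ in more than one place.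

The compounds shown leave open how a chloro or methoxy group in the place of the fluoro would read on either core. They also leave open whether a shorter alkyl chain or a piperidine at the chain end would alter the size of the step from 4-fluorobenzyl to benzyl.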